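The compounds below may be only part of what the source reports. "The series", "measured", "known", "first", "only" and "open" are said of these compounds alone.

Measured so far:
compound 1 `C=CC[C@H]1C[C@]2([C@@H](C)Cc3ccc(OC)c(OC)c3)OCOC2=CC1=O`: 260 nM
compound 2 `C=CC[C@H]1C[C@]2([C@@H](C)Cc3ccc(OC)c(F)c3)OCOC2=CC1=O`: 90 nM

In a functional assay on NCI-H460 cells (Homo sapiens) for antiproliferative activity, with a stated time of 72 h (on this read-out lower numbers stand for stronger inhibition and higher numbers for weaker inhibition), compound 2 gives 90 nM and holds the lowest of the two numbers recorded. The nearest is compound 1, which in this assay gives 260 nM; the step of a 2.9-fold lower number from compound 1 to compound 2 (0.46 log units; beyond the scatter) is modest but beyond the scatter.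

Compound 3 `C=CC[C@H]1C[C@]2([C@@H](C)Cc3ccc(OC)c(O)c3)OCOC2=CC1=O` is not yet measured. It differs from compound 2 by hydroxy in place of fluoro on an aromatic carbon, at the position ortho to a methoxy group. For the measured compounds named here, only one measured step touches this position, a 2.9-fold lower number from compound 1 to compound 2 (0.46 log units; beyond the scatter), and it exchanged methoxy for fluoro; no measured compound carries a hydroxy at this place, so the direction of the new step is not fixed by the data. Since the fluoro that gave the lower number leaves, a partial return toward the number of compound 1 is expected, with wide uncertainty. For compound 3 a step of a 2.2-fold higher number from compound 2 to compound 3 (0.35 log units; beyond the scatter) is expected, giving an estimate of 200 nM with a range from 70 nM to 600 nM.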

Compound 3, half-maximal inhibitory concentration: 80 nM
For compound 3 the middle estimate is 2.5-fold (0.40 log units) above the measured one, within the range that was stated.
By their numbers in this assay, from the lowest: compounds 3 and 2 (each within the scatter of the next); then compound 1.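

In this assay, the exchange of fluoro for hydroxy at this position (a 1.1-fold lower number from compound 2 to compound 3 (0.05 log units; within the scatter)) leaves the two compounds indistinguishable, so the lower number of compound 2 does not require fluoro, and a hydroxy with its hydrogen-bond donor serves equally well here. Taking the methyl off the oxygen of compound 1 (a 3.3-fold lower number from compound 1 to compound 3 (0.51 log units; beyond the scatter)) shows that methoxy at this place, ortho to a methoxy group, stands apart from both smaller groups, an observation that rests on these three compounds alone. No measurement is available that would explain why hydroxy and fluoro match at this position.

The compounds shown leave open whether an amine, a chlorine or a plain hydrogen at this position would fall with compound 2 and compound 3 or with compound 1, and whether an ethoxy would stand further from them than methoxy does. They also leave open whether the match between hydroxy and fluoro persists when the remaining methoxy group is exchanged for another group, or when the allyl chain on the shared core is replaced by a longer chain.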